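The source may report more compounds than this note shows. Statements on the series, on what has been measured and on what is new or still open speak of the compounds shown alone.

Measured so far:
- compound 1 `COc1ccc(-c2sc(N(C)C)nc2-c2cc(OC)c(OC)c(OC)c2)cc1`: 7600 nM
- compound 2 `CCOc1ccc(-c2sc(N(C)C)nc2-c2cc(OC)c(OC)c(OC)c2)cc1`: 4150 nM
- compound 3 `COc1ccc(-c2sc(C)nc2-c2cc(OC)c(OC)c(OC)c2)cc1`: 1760 nM

All three numbers come from a functional assay on Jurkat cells (Homo sapiens) for antiproliferative activity, read by MTT assay, with a stated time of 72 h; a lower number here means a stronger inhibitor, a higher number a weaker inhibitor. Compound 3 carries the lowest number of the three, and both of its gaps to the others are beyond the scatter.

Two changes are traced among the measured compounds. From compound 1 to compound 2 the change is methyl in place of hydrogen on a saturated chain carbon bound to an oxygen on an aromatic ring; it gave a 1.8-fold lower number from compound 1 to compound 2 (0.26 log units; within the scatter). The two cores differ by methyl in place of dimethylamino on an aromatic carbon; that step reads a 4.3-fold lower number from compound 1 to compound 3 (0.64 log units; beyond the scatter).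

Compound 4 `CCOc1ccc(-c2sc(C)nc2-c2cc(OC)c(OC)c(OC)c2)cc1` is not yet measured in this assay. It stands to compound 3 as compound 2 stands to compound 1: the change is methyl in place of hydrogen on a saturated chain carbon bound to an oxygen on an aromatic ring, and the place described for it is the same, word for word, as the place described for the change from compound 1 to compound 2. The series therefore holds this change twice, once measured and once open.

The expectation for compound 4 rests on the measured instance: since the change gave a 1.8-fold lower number from compound 1 to compound 2 (0.26 log units; within the scatter), a step of similar size is expected from compound 3 to compound 4, namely a 1.6-fold lower number from compound 3 to compound 4 (0.20 log units; within the scatter). Among the compounds with values here, for compound 4 the estimated number is 1100 nM, with a range from 500 nM to 2500 nM, the width reflecting that the only precedent lies within the scatter.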

Compound 4, half-maximal inhibitory concentration: 1740 nM
For compound 4 the middle estimate is 1.6-fold (0.20 log units) below the measured one; the range from low to high includes it.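

In this assay, methoxy to ethoxy on the core carrying methyl gives a 1.0-fold lower number from compound 3 to compound 4 (0.00 log units; within the scatter), and the two instances of this change do not differ: the same change on two cores in this assay, a 1.8-fold lower number (0.26 log units; within the scatter) from compound 1 to compound 2 and a 1.0-fold lower number (0.00 log units; within the scatter) from compound 3 to compound 4, 1.8-fold (0.26 log units) apart, within the scatter of two such steps.
Methyl in place of dimethylamino, now read on the ethoxy compounds, gives a 2.4-fold lower number from compound 2 to compound 4 (0.38 log units; beyond the scatter), and it too carries over between the two cores: the same change on two cores in this assay, a 4.3-fold lower number (0.64 log units; beyond the scatter) from compound 1 to compound 3 and a 2.4-fold lower number (0.38 log units; beyond the scatter) from compound 2 to compound 4, 1.8-fold (0.26 log units) apart, within the scatter of two such steps.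
Within these four compounds the two changes therefore behave alike on both cores, with the ethoxy step staying within the scatter each time and the methyl step staying beyond it; this does not show that ethoxy improves on methoxy, and each change rests on a single pair of instances, which says nothing about other cores.

Open, from the compounds shown here alone, is whether a longer chain, such as propoxy, at the same place on the aromatic ring would move the number beyond the scatter. Also open, going by these compounds, is how an amine or a carboxylic acid in place of the methyl on the aromatic carbon would read.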